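Methoxycarbonyl Added to Two Related Amide Scaffolds

The compounds below may be only part of what the source reports. "The series", "measured", "known", "first", "only" and "open" are said of these compounds alone.

Compound 1 `Cc1cc(C)cc(S(=O)(=O)n2c(OCC(=O)Nc3ccccc3Cl)nc3ccccc32)c1` and compound 2 `COC(=O)c1ccc(NC(=O)COc2nc3ccccc3n2S(=O)(=O)c2cc(C)cc(C)c2)c(Cl)c1` share one scaffold and differ in a single place: methoxycarbonyl in place of hydrogen on an aromatic carbon. In an ADME assay on MT4 cells (Homo sapiens) for cytotoxicity, read by MTT assay, with a stated time of 5 days (a higher number here means that more compound is tolerated, a lower number that less compound is tolerated), compound 1 gives 169000 nM, while compound 2 gives 119000 nM. The step of a 1.4-fold lower number from compound 1 to compound 2 (0.15 log units; within the scatter) shows that adding this group left the tolerated concentration essentially unchanged.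

Compound 3 `Cc1cc(C)cc(S(=O)(=O)n2c(SCC(=O)Nc3ccccc3Cl)nc3ccccc32)c1` rests on a second core; how the core of compound 3 differs from the core of compound 1 is not broken down here. In this assay compound 3 gives 107000 nM, a value that sits close to those of compound 1 and compound 2.

Compound 4 `COC(=O)c1ccc(NC(=O)CSc2nc3ccccc3n2S(=O)(=O)c2cc(C)cc(C)c2)c(Cl)c1` is compound 3 carrying the same change that turned compound 1 into compound 2: methoxycarbonyl in place of hydrogen on an aromatic carbon. The group enters at a place described in exactly the same words in both pairs, so this is the same change made on a second core.

Because the step of a 1.4-fold lower number from compound 1 to compound 2 (0.15 log units; within the scatter) stayed within the usual spread of repeat measurements, a step of similar size, a 1.4-fold lower number from compound 3 to compound 4 (0.15 log units; within the scatter), is expected for compound 4 in this assay. Compound 4 is therefore estimated to give 76000 nM, most likely between 40000 nM and 150000 nM.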

Compound 4, half-maximal cytotoxic concentration: 145000 nM
Compound 4: middle estimate off by 1.9-fold (0.28 log units), on the low side; measured number inside the range.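

In this assay, adding methoxycarbonyl to compound 3 gives a step of a 1.4-fold higher number from compound 3 to compound 4 (0.13 log units; within the scatter), so on this second core, too, the change leaves the tolerated concentration without a clear shift. Set beside the earlier step, the two results agree as far as the assay can tell, even though their printed directions are opposite: the same change on two cores in this assay, a 1.4-fold lower number (0.15 log units; within the scatter) from compound 1 to compound 2 and a 1.4-fold higher number (0.13 log units; within the scatter) from compound 3 to compound 4, 1.9-fold (0.28 log units) apart, within the scatter of two such steps. Among the compounds shown here, this supports carrying the change between these two cores without a measurable penalty in tolerated concentration, but it rests on only two pairs, and it shows neither a true direction for the step nor that other cores would behave the same way.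

The compounds shown carry only methoxycarbonyl at this place, so it remains open whether a carboxylic acid or a longer ester such as ethoxycarbonyl would also leave the number within the usual scatter. They also leave open how the same change behaves on a third core.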